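A few compounds are considered here, and "the series" means these few. Any claim that something is new, unique, unknown or untested is made for them only; others in the source may bear on it.

Notes on the series. In a functional assay on HeLa cells (Homo sapiens) for cytotoxicity, read by MTT assay, with a stated time of 48 h (a lower number here means a stronger inhibitor, a higher number a weaker inhibitor), compound 3 (`CCOC(=O)[C@@]1(C(=O)NCc2ccc(C)cc2)C[C@@H]1c1cc(OC)c(OC)c(OC)c1`) reads > 100000 nM as a limit of the assay and not as a number. This is the limit of > 100000 nM in this assay, at which 1 of the 3 values shown sits, and it gives no exact size for any step that starts from compound 3.

The change to compound 4 (`COc1cc([C@H]2C[C@@]2(CO)C(=O)NCc2ccc(C)cc2)cc(OC)c1OC`) puts hydroxymethyl in place of ethoxycarbonyl on a saturated ring carbon. For the measured compounds named here, no measured step covers this exchange directly. The nearest evidence comes from the two measured hydroxymethyl compounds. Compound 1 (`COc1cc([C@@H]2C[C@]2(CO)C(=O)NCc2ccc(C)cc2)cc(OC)c1OC`) gives 17400 nM and compound 2 (`COc1cc([C@H]2C[C@]2(CO)C(=O)NCc2ccc(C)cc2)cc(OC)c1OC`) gives 57800 nM in this assay as numbers, which compound 3 does not.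

Going by the values given here, the one measured step is a 3.3-fold higher number from compound 1 to compound 2 (0.52 log units; beyond the scatter) and it comes with the fact that compounds 1 and 2 differ only in the configuration as drawn in this pair. Configuration therefore has to be allowed for in compound 4, and the width of the range reflects this.

Going by these compounds, a step beyond the scatter is expected, towards a lower number, though its exact size stays open while one end is only a limit. The estimated step is an at least 3.0-fold lower number from compound 3 to compound 4 (0.48 log units; beyond the scatter) on this reading. For compound 4 the expected value is 33000 nM with an estimated range from 12000 nM to 90000 nM in all.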

Compound 4, half-maximal inhibitory concentration: > 100000 nM
Compound 4: no number, only a limit; the forecaster's own chance of this, stated with the estimate: 15%; middle value at least 3.0-fold (0.48 log units) from the limit.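

In this assay compound 4 reads > 100000 nM, a limit of the assay and not a number. The exchange of ethoxycarbonyl for hydroxymethyl on this saturated ring carbon therefore cannot be read as a step, because compounds 3 and 4 both sit at the limit: the limit of > 100000 nM in this assay, at which 2 of the 4 values shown sit. Hydroxymethyl at this position does not by itself secure a measurable reading, since configuration alone gives an at least 5.7-fold higher number from compound 1 to compound 4 (0.75 log units; beyond the scatter) for the mirror-image pair, whereas an at least 1.7-fold higher number from compound 2 to compound 4 (0.23 log units; that floor lies within the scatter) leaves a floor that does not separate compound 4 from compound 2.

Going by these compounds, how far compound 4 lies beyond its limit stays open, and with it the full size of both configuration steps. Also open, on these data alone, is whether a carboxylic acid or an aminomethyl group on the same saturated ring carbon, in the configuration of compound 1, would give a number in this assay and how that number would compare with the hydroxymethyl reading of compound 1.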